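Swapping chloro for methoxy on compound 2

The source may hold more compounds than are shown below. What is called first, only, known or untested is meant among the compounds shown, and "the series" means these compounds.

Measured so far:
compound 1 `COc1cc(OC)c(Cl)c(-c2ccc3c(NC(=O)c4ccc(N5CCCCC5)cc4)n[nH]c3n2)c1Cl` gives 558 nM
compound 2 `COc1cc(OC)c(Cl)c(-c2ccc3c(NC(=O)c4ccc(N5CCN(C)CC5)c(Cl)c4)n[nH]c3n2)c1Cl` gives 191 nM

In a functional assay on NCI-H1581 cells (Homo sapiens) for antiproliferative activity, read by CCK-8 assay, with a stated time of 72 h (a lower number here means a stronger inhibitor, a higher number a weaker inhibitor), compound 2 holds the lower of the two numbers, and compound 1 stands above it by a gap beyond the scatter. Among the measured compounds shown here, these two compounds differ in more than one place, so no measured step shows the effect of a single change.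

The next compound is compound 3 `COc1cc(C(=O)Nc2n[nH]c3nc(-c4c(Cl)c(OC)cc(OC)c4Cl)ccc23)ccc1N1CCN(C)CC1`, which keeps everything in compound 2 except for one substituent. Methoxy comes in place of chloro on an aromatic carbon, ortho to a 4-methylpiperazin-1-yl group and meta to a large group: methoxy in place of chloro on an aromatic carbon. The measured compounds give no evidence for a direction, so no change beyond the scatter is expected in this assay. The expectation therefore stays anchored on compound 2 at 191 nM and is held loosely. The expected move, a 1.0-fold higher number from compound 2 to compound 3 (0.02 log units; within the scatter), is accordingly small. For compound 3 the estimated value is 200 nM (range 75 nM to 550 nM).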

Compound 3, half-maximal inhibitory concentration: 15.6 nM
Beside the measured number, compound 3's estimate is 13-fold (1.11 log units) above it; the measured number lies below the stated range.
By their numbers in this assay, from the lowest: compound 3; then compound 2; then compound 1.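

Among the compounds shown here, the first single-place step falls on the aromatic carbon ortho to a 4-methylpiperazin-1-yl group and meta to a large group: in this assay, methoxy in place of chloro gives a 12-fold lower number from compound 2 to compound 3 (1.09 log units; beyond the scatter) and this step is large, well beyond the scatter. This position is therefore not indifferent to its substituent, since exchanging a single chlorine for methoxy, with its one added hydrogen-bond acceptor, moves the number this far while the rest of compound 2 stays unchanged. No measurement at hand bears on why the step is so large, and its origin stays unassigned.

As far as these compounds go, with only chloro and methoxy read at this position, it remains open whether the step is specific to methoxy or would also appear with other groups there, such as fluoro, hydroxy or ethoxy. Compound 1 differs from both other compounds in more than one place, so it cannot show whether the same step would hold with a piperidine in place of the 4-methylpiperazin-1-yl group.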